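Halogen swap on the fused ring: cytotoxicity working notes

The compounds below may be only part of what the source reports. "The series", "measured", "known", "first", "only" and "open" are said of these compounds alone.

Measured so far:
compound 1, `CS(=O)(=O)Nc1ccc2c(c1)S(=O)(=O)C=C(c1c(O)c3ccccc3n(Cc3ccc(F)cc3)c1=O)N2` — > 50000 nM
compound 2, `CS(=O)(=O)Nc1ccc2c(c1)S(=O)(=O)C=C(c1c(O)c3ccc(F)cc3n(Cc3ccc(F)cc3)c1=O)N2` — > 50000 nM

In an ADME assay on 2209-23 cells (Homo sapiens) for cytotoxicity, read by WST assay (on this read-out higher numbers stand for lower toxicity in this test and lower numbers for higher toxicity in this test), compound 1 returns only a limit, > 50000 nM. In this assay compound 2 also returns only a limit, > 50000 nM. Compound 2 therefore stands at the top edge of what the numbers show; both values shown sit at the limit of > 50000 nM in this assay, at which 2 of the 2 values shown sit, so the two compounds cannot be ordered against each other. Among the compounds with values here, the single measured step, a step that the two limits leave unreadable from compound 1 to compound 2, is a fluoro in place of hydrogen on an aromatic carbon, and its size cannot be read.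

Not yet measured is compound 3, `CS(=O)(=O)Nc1ccc2c(c1)S(=O)(=O)C=C(c1c(O)c3ccc(Cl)cc3n(Cc3ccc(F)cc3)c1=O)N2`. It differs from compound 2 by chloro in place of fluoro on an aromatic carbon. Within the data shown here, the one step that bears on this change is unreadable, so there is no basis for expecting a step beyond the scatter in either direction in this assay; the expected step is a step that the limit leaves unreadable from compound 2 to compound 3. Compound 3 is expected to give 60000 nM in this assay, within 30000 nM to 150000 nM, and most likely again only as a limit.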

Compound 3, half-maximal cytotoxic concentration: > 50000 nM
Compound 3: only a limit was reported (the forecaster's own chance of this, stated with the estimate: 80%); the middle value lies beyond the limit too.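

Compound 3 returns only a limit, so its steps from compound 2 and from compound 1 cannot be read in this assay, and compound 1, compound 2 and compound 3 all end at the same edge: the limit of > 50000 nM in this assay, at which 3 of the 3 values shown sit. The compounds shown leave open whether hydrogen, fluoro and chloro at this place differ at all in this assay.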